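The source may report more compounds than this note shows. Statements on the series, on what has been measured and on what is new or still open speak of the compounds shown alone.

Measured so far in an assay on isolated protein for inhibition of DNA topoisomerase 1 (Homo sapiens), with a stated time of 15 min; a lower number here means a stronger inhibitor, a higher number a weaker inhibitor:
- compound 1 `COc1c(N2CC[C@@H](CN)C2)c(F)cc2c(=O)c(C(=O)O)cn(Cc3ccc(-c4ccc(F)cc4)cc3)c12`: 60900 nM
- compound 2 `COc1c(N2CC[C@@H](CO)C2)c(F)cc2c(=O)c(C(=O)O)cn(Cc3ccc(-c4ccccc4)cc3)c12`: only a limit, > 200000 nM
- compound 3 `CNCCCCNc1c(F)cc2c(=O)c(C(=O)O)cn(Cc3ccc(-c4ccccc4)cc3)c2c1OC`: only a limit, > 200000 nM

Compound 3 stands at the limit of this assay, and no number is known for it. Compound 2 also gives only a limit in this assay, > 200000 nM. Within the data shown here, because of that, the step that the two limits leave unreadable from compound 2 to compound 3 cannot be read, and the only numerical value in the set is that of compound 1 in this assay, 60900 nM. Evidence on the shared plateau: the limit of > 200000 nM in this assay, at which 2 of the 3 values shown sit.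

Compound 4 `COc1c(N2CC[C@@H](CN)C2)c(F)cc2c(=O)c(C(=O)O)cn(Cc3ccc(-c4ccccc4)cc3)c12` is the next member. Relative to compound 3 the change is 3-(aminomethyl)pyrrolidin-1-yl in place of (4-(methylamino)butyl)amino on an aromatic carbon. Among the measured compounds shown here, no measured step bears directly on this exchange: the only step recorded, from compound 2 to compound 3, is unreadable, so it gives neither a size nor a direction. What remains is that compound 1, which carries the same 3-(aminomethyl)pyrrolidin-1-yl group, gives a number rather than a limit in this assay, 60900 nM.

Compound 4 is therefore expected to come off the limit, with an estimated value of 90000 nM (range 30000 nM to 250000 nM). The step this estimate means, an at least 2.2-fold lower number from compound 3 to compound 4 (0.34 log units; beyond the scatter), is expected to be a gain in potency, though its size stays uncertain since compound 3 has only a limit.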

Compound 4, half-maximal inhibitory concentration: 26000 nM
Compound 4: the middle estimate sits 3.5-fold (0.54 log units) above what was measured; measured number outside the range, below it.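

In this assay, 3-(aminomethyl)pyrrolidin-1-yl in place of (4-(methylamino)butyl)amino, on the aromatic carbon ortho to a fluoro group and ortho to a methoxy group, gives an at least 7.6-fold lower number from compound 3 to compound 4 (0.88 log units; beyond the scatter), so at this position the ring-bearing group reads as a number where the open chain gives only a limit. Keeping that ring and putting amino in place of hydroxy on the saturated chain carbon gives an at least 7.6-fold lower number from compound 2 to compound 4 (0.88 log units; beyond the scatter), which ties the gain to the terminal amino group as well as to the ring. Hydrogen in place of fluoro on an aromatic carbon gives a 2.3-fold lower number from compound 1 to compound 4 (0.37 log units; beyond the scatter), a modest step that leaves compound 4 as the strongest inhibitor of the four shown.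

On these data alone, the step between compound 2 and compound 3 cannot be read, and the true sizes of the steps from those two compounds to compound 4 remain open: the limit of > 200000 nM in this assay, at which 2 of the 4 values shown sit. Also open is whether a longer aminoalkyl chain on the pyrrolidine ring, a piperazine at the same aromatic carbon, or a methylamino group in place of the primary amine would extend this gain.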